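The source may hold more compounds than are shown below. What is called first, only, known or untested is meant among the compounds shown, and "the series" means these compounds.

In a functional assay on cells (leukaemia cell line, Homo sapiens) for inhibition, read by sulforhodamine B assay, with a stated time of 48 h (on this read-out lower numbers stand for stronger inhibition of growth and higher numbers for weaker inhibition of growth), compound 1 `O=S(=O)(Nc1cccc(Cl)c1)c1ccc(-c2cnc(C3CC3)o2)cc1` gives 54200 nM, the smallest of the three numbers measured, though both companions sit within the scatter of it: compound 2 `O=S(=O)(Nc1cc(F)cc(F)c1)c1ccc(-c2cnc(C3CC3)o2)cc1` gives 80000 nM and compound 3 `COc1cc(NS(=O)(=O)c2ccc(-c3cnc(C4CC4)o3)cc2)ccc1F` gives 75700 nM. The change leading to compound 4 `O=S(=O)(Nc1ccc(I)c(Cl)c1)c1ccc(-c2cnc(C3CC3)o2)cc1` is iodo in place of hydrogen on an aromatic carbon. Among the measured compounds shown here, the steps that bear on it are those which exchanged the group on the sulfonamide nitrogen: a 1.5-fold higher number from compound 1 to compound 2 (0.17 log units; within the scatter), a 1.4-fold higher number from compound 1 to compound 3 (0.15 log units; within the scatter) and, between those two variants, a 1.1-fold lower number from compound 2 to compound 3 (0.02 log units; within the scatter). None of them moved the number beyond the scatter, so the added iodo is expected to give no step beyond the scatter either. Compound 4 is therefore estimated at 45000 nM, between 18000 nM and 110000 nM, which means an expected 1.2-fold lower number from compound 1 to compound 4 (0.08 log units; within the scatter).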

Compound 4, concentration for total growth inhibition: 19600 nM
Compound 4: the middle estimate sits 2.3-fold (0.36 log units) above what was measured, and the stated range covers the measured number.
By their numbers in this assay, from the lowest: compound 4; then compounds 1, 3 and 2 (each within the scatter of the next).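

Iodo in place of hydrogen, on the aromatic carbon ortho to a chloro group and para to a large group, is the first change in this assay to move the number beyond the scatter (a 2.8-fold lower number from compound 1 to compound 4 (0.44 log units; beyond the scatter)). The 3-chloro-4-iodophenyl group also separates from the other two groups on the sulfonamide nitrogen (a 3.9-fold lower number from compound 3 to compound 4 (0.59 log units; beyond the scatter); a 4.1-fold lower number from compound 2 to compound 4 (0.61 log units; beyond the scatter)). No measurement available here accounts for these steps.

On these data alone, it remains open whether iodo would give such a step without the chloro group, and whether bromo or an amine on that carbon would match it.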